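This account rests on a few compounds, and the source may have more. Where it says the series, first, only, none or still open, it means among the compounds named here.

In a functional assay for agonist activity at G protein-coupled receptor 88 (Homo sapiens), read by HTRF and cAMP accumulation (on this read-out higher numbers stand for an effect only at larger amounts of compound and lower numbers for an effect already at smaller amounts), three compounds have been measured. Compound 1 `CN[C@@H](CC(C)C)CN(C(=O)[C@@H]1C[C@H]1c1ccccc1)c1ccc(-c2ccccc2)cc1` gives 2 nM, compound 2 `CC[C@H](C)[C@H](N)CN(C(=O)[C@@H]1C[C@H]1c1cc(F)cc(F)c1)c1ccc(-c2ccccc2)cc1` gives 960 nM, and compound 3 `CC(C)C[C@H](N)CN(C(=O)[C@@H]1C[C@H]1c1ccccc1)c1ccc(-c2ccncc2)cc1` gives 13000 nM, the highest of the three numbers. Compound 4 `CC(C)C[C@H](N)CN(C(=O)[C@@H]1C[C@H]1c1ccccc1)c1ccc(-c2ccccc2F)cc1` has not yet been measured in this assay. It differs from compound 3 in one place: 2-fluorophenyl in place of pyridin-4-yl on an aromatic carbon. Among the measured compounds shown here, no two measured compounds differ in just one place, so no single step of this kind is on record; compounds 1 and 2 give lower numbers than compound 3 but differ from it elsewhere as well. The step from compound 3 to compound 4 is expected to be a 26-fold lower number from compound 3 to compound 4 (1.41 log units; beyond the scatter), toward a lower number. The main support is compound 2, which carries a six-membered aromatic ring of carbon only in that position and gives 960 nM. Compound 4 is therefore estimated at 500 nM, within a range from 100 nM to 3000 nM.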

Compound 4, half-maximal effective concentration: 1600 nM
Beside the measured number, compound 4's estimate is 3.2-fold (0.51 log units) below it, within the range that was stated.
By their numbers in this assay, from the lowest: compound 1; then compounds 2 and 4 (each within the scatter of the next); then compound 3.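

In this assay, among the compounds shown here, placing 2-fluorophenyl instead of pyridin-4-yl on the aromatic carbon para to a large group gives an 8.1-fold lower number from compound 3 to compound 4 (0.91 log units; beyond the scatter), the first single-place step here, so the group at this position matters to the read-out. The swap removes the ring nitrogen and adds a fluorine in one move, and the step cannot separate the two. No measurement at hand explains the change. Still open, as far as these compounds go, is how groups such as 4-fluorophenyl or pyridin-3-yl would read at this position. From the compounds shown here alone, whether this step holds on other versions of the core also remains unknown.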